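The source may report more compounds than this note shows. Statements on the series, on what has been measured and on what is new or still open speak of the compounds shown alone.

Measured so far:
compound 1 `Nc1ncnc2c1ncn2[C@@H]1O[C@H](COC(=O)OCc2ccccc2)[C@@H](O)[C@H]1O` — > 100000 nM
compound 2 `Nc1ncnc2c1nc(NCCCc1ccccc1)n2[C@@H]1O[C@H](CO)[C@@H](O)[C@H]1O` — 536000 nM
compound 3 `Nc1ncnc2c1nc(NCc1cccc(Cl)c1)n2[C@@H]1O[C@H](CO)[C@@H](O)[C@H]1O` — 5400 nM

Compound 1 is known in an assay on COS-7 cells for inhibition of sodium/nucleoside cotransporter 2 (Homo sapiens), read by scintillation counting, in the presence of a further agent that is not named here (a lower number here means a stronger inhibitor, a higher number a weaker inhibitor), only as a limit, > 100000 nM, sitting at the limit of > 100000 nM in this assay, at which 1 of the 3 values shown sits, so no number exists for it. For the measured compounds named here, compound 2 gives 536000 nM and compound 3 gives 5400 nM; the single measured step, a 99-fold lower number from compound 2 to compound 3 (2.00 log units; beyond the scatter), concerns the group on the nitrogen of the shared core and so a different position from the one changed here.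

Compound 4 `CNC(=O)OC[C@H]1O[C@@H](n2cnc3c(N)ncnc32)[C@H](O)[C@@H]1O` is not yet measured. It differs from compound 1 by methylamino in place of benzyloxy on a carbonyl carbon. Going by the values given here, no measured step touches this position, and the only reference point, compound 1, is a limit rather than a number. The expectation therefore rests on compound 1 alone: compound 4 is expected to stay weak, with an expected step that the limit leaves unreadable from compound 1 to compound 4, and a reading that again ends at a limit seems the more likely outcome. The estimate for compound 4 is 200000 nM, with a range from 50000 nM to 1000000 nM.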

Compound 4, half-maximal inhibitory concentration: > 100000 nM
Compound 4: a limit, no number (the forecaster's own chance of this, stated with the estimate: 70%); the middle value does not contradict the limit.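

Compound 1 and compound 4 both end at a limit rather than a number, so no step between them can be read: the limit of > 100000 nM in this assay, at which 2 of the 4 values shown sit.

The compounds shown leave open how methylamino and benzyloxy on this carbonyl carbon compare in strength of inhibition.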